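A few compounds are considered here, and "the series" means these few. Any claim that something is new, unique, unknown or untested is made for them only; others in the source may bear on it.

Compound 1 `CS/C(=N\C(=O)c1csc([N+](=O)[O-])c1)NC(=O)c1csc([N+](=O)[O-])c1`: in a functional assay on HepG2 cells (Homo sapiens) for cytotoxicity, read by MTT assay, with a stated time of 72 h (on this read-out lower numbers stand for stronger inhibition of growth and higher numbers for weaker inhibition of growth), compound 1 gives only a limit, > 100000 nM.
Compound 2 `O=C(/N=C(/NC(=O)c1cc(-c2ccccc2)nc2ccccc12)[Se]Cc1ccccc1)c1cc(-c2ccccc2)nc2ccccc12`: in this assay compound 2 gives 52400 nM.
Compound 3 `CS/C(=N\C(=O)c1cc(-c2ccccc2)nc2ccccc12)NC(=O)c1cc(-c2ccccc2)nc2ccccc12`: in this assay compound 3 gives 48200 nM.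

Compound 2 differs from compound 3 by a group of 8 heavy atoms (7 carbon, 1 selenium; one six-membered aromatic ring of carbon only) in place of a group of 2 heavy atoms (1 carbon, 1 sulfur; no ring), on a carbon with a double bond to nitrogen, and this change gives a 1.1-fold higher number from compound 3 to compound 2 (0.04 log units; within the scatter). Compound 4 `O=C(/N=C(/NC(=O)c1csc([N+](=O)[O-])c1)[Se]Cc1ccccc1)c1csc([N+](=O)[O-])c1`, not yet measured, differs from compound 1 by a group of 8 heavy atoms (7 carbon, 1 selenium; one six-membered aromatic ring of carbon only) in place of a group of 2 heavy atoms (1 carbon, 1 sulfur; no ring), on a carbon with a double bond to nitrogen, the same change on a different core; the difference between the two cores is not broken down here. Going by the values given here, the only value of compound 1 is a limit, (the limit of > 100000 nM in this assay, at which 1 of the 3 values shown sits). Because a 1.1-fold higher number from compound 3 to compound 2 (0.04 log units; within the scatter) shows the change leaving the number about unchanged on the other core, compound 4 is expected to show a step that the limit leaves unreadable from compound 1 to compound 4. Compound 4 is therefore estimated at 150000 nM, most likely again reported as a limit rather than a number, between 60000 nM and 400000 nM.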

Compound 4, concentration for total growth inhibition: 62800 nM
Estimate against measurement, compound 4: 2.4-fold (0.38 log units) above; low and high end bracket the measured number.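

In this assay, the group holding selenium and a six-membered aromatic ring in place of methylsulfanyl gives an at least 1.5-fold lower number from compound 1 to compound 4 (0.20 log units; that floor lies within the scatter), and only this floor can be read. Going by these compounds, compound 1 gives only a limit, > 100000 nM, so the full size of this step stays unknown. The change is therefore shown neither to act alike on the two cores nor to act differently: the same change on two cores in this assay, a 1.1-fold higher number (0.04 log units; within the scatter) from compound 3 to compound 2 and an at least 1.5-fold lower number (0.20 log units; that floor lies within the scatter) from compound 1 to compound 4; the limit leaves it open whether they differ

The compounds shown leave open what a benzylsulfanyl group would give on the carbon with a double bond to nitrogen, which would help separate the part played by selenium from that of the ring. On these data alone, how an amine in the same place would compare also remains open.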